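Compound 4: an ethyl fluorophenyl amine variant

The source may hold more compounds than are shown below. What is called first, only, known or untested is meant among the compounds shown, and "the series" means these compounds.

Compound 1 `COc1ccc(N(C)Cc2nc3cc(C(F)(F)F)ccc3nc2-c2ccccc2)cc1` gives 3000 nM
Compound 2 `CN(Cc1nc2cc(C(F)(F)F)ccc2nc1-c1ccccc1)c1ccc(OC(F)(F)F)cc1` gives 3000 nM
Compound 3 `COc1ccc(N(C)Cc2nc3cc(C(F)(F)F)ccc3nc2-c2ccccc2)cc1OC` gives 8000 nM

In an assay on isolated protein for inhibition of Dihydrofolate reductase (Homo sapiens), read by spectrophotometry (a lower number here means a stronger inhibitor, a higher number a weaker inhibitor), compound 1 stands level with compound 2, and together they hold the lowest numbers of the three; compound 3 sits higher, the step being a 2.7-fold higher number from compound 1 to compound 3 (0.43 log units; beyond the scatter). Compound 4 `CCN(Cc1nc2cc(C(F)(F)F)ccc2nc1-c1ccccc1)c1ccc(F)cc1` differs from compound 1 by ethyl(4-fluorophenyl)amino in place of (4-methoxyphenyl)(methyl)amino on a saturated chain carbon bound to an aromatic carbon. Going by the values given here, two measured steps bear on this. The step of no change at the digits printed from compound 1 to compound 2 (within the scatter) shows that changing the group on the oxygen of that ring left this assay unchanged, while a 2.7-fold higher number from compound 1 to compound 3 (0.43 log units; beyond the scatter) shows that adding a second methoxy cost a modest amount. Neither step removes the methoxy entirely or lengthens the methyl on the nitrogen, so the present change is only loosely covered. The expectation is therefore a step within the scatter, a 1.2-fold higher number from compound 1 to compound 4 (0.07 log units; within the scatter), and compound 4 is estimated at 3500 nM in this assay, with a range from 1500 nM to 8000 nM.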

Compound 4, inhibition constant: 3000 nM
For compound 4 the middle estimate is 1.2-fold (0.07 log units) above the measured one, within the range that was stated.
By their numbers in this assay, from the lowest: compounds 1, 2 and 4 (each within the scatter of the next); then compound 3.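

In this assay, the swap to ethyl(4-fluorophenyl)amino on this saturated chain carbon gives a flat result (no change at the digits printed from compound 1 to compound 4 (within the scatter)). The amine group here therefore tolerates losing the methoxy, gaining fluorine on the ring and having ethyl replace methyl on the nitrogen, all as one combined change. Nothing measured here offers a reason for this result. As far as these compounds go, what each of these edits does alone stays open. So does whether a longer chain such as propyl on the nitrogen, or a chlorine or nitrile in place of the fluorine, would leave the number unmoved.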